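Swapping Chloro for Methoxy on a Modulator Scaffold

The compounds below may be only part of what the source reports. "The series", "measured", "known", "first", "only" and "open" are said of these compounds alone.

Of the compounds shown here, two sharing one core have been tested in a functional assay on CHO cells for positive allosteric modulation of metabotropic glutamate receptor 2 (Homo sapiens), read by scintillation counting and GTPgammaS binding, with a stated time of 30 min; a higher number here means a larger maximal response, a lower number a smaller maximal response. Compound 1, `COc1cccc(-c2ccn(CCC(C)C)c(=O)c2C#N)c1`, gives 176% in this assay. Compound 2, `COc1ccc(-c2ccn(CCC(C)C)c(=O)c2C#N)cc1Cl`, gives 200% in this assay, which is the higher of the two numbers, lying above compound 1 by a margin that exceeds the usual scatter of such measurements. Compound 2 therefore marks the top of what has been measured here.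

Compound 3, `COc1ccc(-c2ccn(CCC(C)C)c(=O)c2C#N)cc1OC`, has not yet been measured. It differs from compound 2 in a single place: methoxy in place of chloro on an aromatic carbon. Whether this swap helps or hurts cannot be read from the two measured compounds, since neither of them carries this particular change against the other. For the measured compounds named here, the only guide is that both measured compounds already reach a large maximal response, so a drastic collapse seems unlikely. A small downward step from compound 2 to compound 3 in this assay is expected, around a number 20 percentage points lower from compound 2 to compound 3 (beyond the scatter), possibly within the scatter. Compound 3 is accordingly estimated to give 180% in this assay, with a plausible range from 145% to 215%.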

Compound 3, largest response reached (Emax), in percent of the reference or control that the assay uses: 242%
For compound 3 the middle estimate is 62 percentage points below the measured one; measured number above the stated range.
By their numbers in this assay, from the lowest: compound 1; then compound 2; then compound 3.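

In this assay, methoxy in place of chloro on the aromatic carbon ortho to a methoxy group and meta to a large group gives a number 42 percentage points higher from compound 2 to compound 3 (beyond the scatter), the first step among these compounds that isolates a change at this position and shows that chloro is not the best of the groups seen there. Methoxy in place of hydrogen on an aromatic carbon gives a number 66 percentage points higher from compound 1 to compound 3 (beyond the scatter), so with both steps pointing the same way and both beyond the scatter, compound 3 stands highest of the three in maximal response. Nothing available here explains why methoxy gives the larger response in these two comparisons.

As far as these compounds go, it remains open whether the gain is specific to methoxy at this aromatic carbon or would carry over to a longer ether such as ethoxy, to a hydroxyl group or to an amine. Also open, from the compounds shown here alone, is how far the high maximal response depends on the chain attached to the shared core, and what concentration of compound 3 is needed to reach that response.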